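This account rests on a few compounds, and the source may have more. Where it says the series, first, only, none or still open, it means among the compounds named here.

Measured so far in an ADME assay on the whole organism (Mus musculus, strain Swiss Webster) for pharmacokinetics, read by LC-MS, at a dose of 50 mg/kg by the oral route; on this read-out lower numbers stand for lower exposure and higher numbers for higher exposure at the dose given:
- compound 1 `O=C(Nc1ccc(F)c(-c2nc3ncc(-c4ccc(F)c(F)c4)cc3[nH]2)c1)N1CCCC1` gives 6670 nM
- compound 2 `O=C(Nc1ccc(F)c(-c2nc3ncc(-c4cccc(F)c4F)cc3[nH]2)c1)N1CCCC1` gives 1830 nM

Compound 2 holds the lower of the two numbers, and its gap to compound 1 lies beyond the scatter. Going by the values given here, compound 3 `O=C(Nc1ccc(F)c(-c2nc3ncc(-c4cccnc4F)cc3[nH]2)c1)N1CCCC1` has no measurement yet. The change from compound 2 is 2-fluoropyridin-3-yl in place of 2,3-difluorophenyl on an aromatic carbon, with the new group on the same aromatic carbon of the shared core.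

Among the compounds with values here, only one measured step touches this group: a 3.6-fold lower number from compound 1 to compound 2 (0.56 log units; beyond the scatter). That step exchanges one difluorophenyl pattern for another and brings no nitrogen into the ring, so it speaks to size but not to direction. Within the data shown here, no measured compound carries a hetero atom in this ring. Among the measured compounds shown here, with a 3.6-fold lower number from compound 1 to compound 2 (0.56 log units; beyond the scatter) as the only guide to size, a step of no greater size is expected in this assay, most likely within the scatter and with no firm direction. The expected change is a 1.1-fold lower number from compound 2 to compound 3 (0.06 log units; within the scatter). Compound 3 is estimated at 1600 nM, with an expected range of 550 nM to 4800 nM.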

Compound 3, maximal plasma concentration: 25600 nM
Beside the measured number, compound 3's estimate is 16-fold (1.20 log units) below it, outside the stated range (above it).
By their numbers in this assay, from the lowest: compound 2; then compound 1; then compound 3.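

In this assay, this aromatic carbon of the shared core tolerates a far larger swing than the exchange of one difluorophenyl pattern for another had shown: the first ring here with a hetero atom, 2-fluoropyridin-3-yl in place of 2,3-difluorophenyl, gives a 14-fold higher number from compound 2 to compound 3 (1.15 log units; beyond the scatter) and so also sets the direction of the change, which is upward. The rise is not merely a recovery of the level held by the 3,4-difluorophenyl group, as the same replacement gives a 3.8-fold higher number from compound 1 to compound 3 (0.58 log units; beyond the scatter) and compound 3 stands beyond the scatter from both of the other compounds. Nothing available on these compounds accounts for the size of this rise.

Compound 3 differs from compound 2 both in the ring nitrogen and in carrying one fluorine fewer, so the shown compounds do not separate these two changes, and a pyridin-3-yl group without fluorine or a plain phenyl group would be needed to do so. Also open, from the compounds shown here alone, is whether the gain depends on where the nitrogen stands, which a pyridin-4-yl or pyrimidin-5-yl group on the same carbon could test.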